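The source may hold more compounds than are shown below. What is called first, only, known or untested is meant among the compounds shown, and "the series" means these compounds.

Compound 2 `O=C(Nc1c(C(O)(C(F)(F)F)C(F)(F)F)ccc2ccccc12)C1CCC1` in a functional assay (Sus scrofa) with sulfonylurea receptors; K-ATP channels (Homo sapiens) as the target (on this read-out lower numbers stand for smaller maximal responses and higher numbers for larger maximal responses), gives 97%. Its two measured neighbours differ from it only at the carbonyl carbon: compound 1 `CCCC(=O)Nc1c(C(O)(C(F)(F)F)C(F)(F)F)ccc2ccccc12` gives 92% in this assay, and compound 3 `COCC(=O)Nc1c(C(O)(C(F)(F)F)C(F)(F)F)ccc2ccccc12` gives 93% in this assay; both numbers sit alongside that of compound 2 within the usual scatter. The next compound, compound 4 `O=C(Nc1c(C(O)(C(F)(F)F)C(F)(F)F)ccc2ccccc12)c1ccco1`, differs from compound 2 as follows: furan-2-yl in place of cyclobutyl on a carbonyl carbon. The measured steps that bear on this change are the two at the same carbonyl carbon, a number 5 percentage points higher from compound 1 to compound 2 (within the scatter) and a number 4 percentage points lower from compound 2 to compound 3 (within the scatter); the remaining comparison, a number 1 percentage points higher from compound 1 to compound 3 (within the scatter), also stays within the scatter. Across propyl, cyclobutyl and methoxymethyl at this position the maximal response therefore hardly moves. Among the measured compounds shown here, no measured step places an aromatic group at this carbon, so the furan-2-yl step opens a new direction; on the evidence of the three steps above, no step beyond the scatter is expected in this assay. For compound 4 the expected value in this assay is 93%, with a range of 80% to 102%, which means an expected step of a number 4 percentage points lower from compound 2 to compound 4 (within the scatter).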

Compound 4, largest response reached (reported as efficacy), in percent of the reference or control that the assay uses: 96%
Compound 4: the middle estimate sits 3 percentage points below what was measured; low and high end bracket the measured number.
By their numbers in this assay, from the lowest: compounds 1, 3, 4 and 2 (each within the scatter of the next).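

In this assay furan-2-yl is the only aromatic group shown on this carbonyl carbon, and replacing each of the saturated groups with it gives steps that all stay within the scatter: a number 1 percentage points lower from compound 2 to compound 4 (within the scatter) and a number 3 percentage points higher from compound 3 to compound 4 (within the scatter) and a number 4 percentage points higher from compound 1 to compound 4 (within the scatter). The carbonyl carbon bound to the amide-type nitrogen thus carries a five-membered aromatic ring with 1 hetero atom, a four-membered non-aromatic ring and open chains with no step beyond the scatter among these compounds. No measured evidence accompanies these numbers to account for the result.

From the compounds shown here alone, whether phenyl, a chain ending in an amine or a carboxylic acid on this carbonyl carbon would give a step beyond the scatter remains open. Changes to the shared core also remain open.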